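The source may report more compounds than this note shows. Statements on the series, on what has been measured and on what is new or still open speak of the compounds shown alone.

Compound 3 `COc1cc(-c2ccnc3cc(-c4ccc(-c5cnn(C)c5)cc4)nn23)cc(OC)c1OC` gives 1150 nM in a functional assay on A549 cells (Homo sapiens) for inhibition, read by CCK-8 assay, with a stated time of 48 h (on this read-out lower numbers stand for stronger inhibition and higher numbers for weaker inhibition), the highest number of the three measured compounds. Compound 1 `COc1cc(-c2ccnc3cc(-c4ccc(C)cc4)nn23)cc(OC)c1OC` gives 3 nM and compound 2 `COc1cc(-c2ccnc3cc(-c4ccc5cc[nH]c5c4)nn23)cc(OC)c1OC` gives 170 nM. The step of a 380-fold higher number from compound 1 to compound 3 (2.58 log units; beyond the scatter) is therefore large, and the step of a 57-fold higher number from compound 1 to compound 2 (1.75 log units; beyond the scatter) is large as well: both replacements of a small group on the shared core of compound 1 by a ring-bearing group raised the number strongly.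

Compound 4 `COc1ccc(-c2cc3nccc(-c4cc(OC)c(OC)c(OC)c4)n3n2)cc1` differs from compound 3 by methoxy in place of 1-methyl-1H-pyrazol-4-yl on an aromatic carbon. This change runs against the direction of the measured step from compound 1 to compound 3, removing the five-membered aromatic ring and leaving a two-heavy-atom group close in size to the methyl of compound 1. Because compound 1 with its methyl gives 3 nM, compound 4 is expected to show a large fall in the number, with a step of about a 77-fold lower number from compound 3 to compound 4 (1.88 log units; beyond the scatter), though a methoxy has not itself been measured here. Compound 4 is therefore estimated at 15 nM, with a likely range from 3 nM to 80 nM.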

Compound 4, half-maximal inhibitory concentration: 376 nM
Compound 4: the middle estimate sits 25-fold (1.40 log units) below what was measured; the whole stated range lies below it.
By their numbers in this assay, from the lowest: compound 1; then compound 2; then compound 4; then compound 3.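

Taking away the 1-methyl-1H-pyrazol-4-yl group in this assay gives only a modest change (a 3.1-fold lower number from compound 3 to compound 4 (0.49 log units; beyond the scatter)), so losing the five-membered aromatic ring does not by itself restore the low number of compound 1. The new contrast lies between two small groups on the same aromatic carbon, para to a large group: methoxy in place of methyl gives a large step (a 130-fold higher number from compound 1 to compound 4 (2.10 log units; beyond the scatter)), so small size alone does not go with the low number. Compound 4 also sits only modestly away from the indole-bearing compound 2 (a 2.2-fold higher number from compound 2 to compound 4 (0.34 log units; beyond the scatter)), which leaves compound 1, with its methyl, apart from the other three compounds.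

Nothing given here accounts for the gap between methyl and methoxy. Open too, from the compounds shown here alone, is whether ethyl, chlorine, a hydroxyl or an amine at this place would fall nearer compound 1 or compound 4.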